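A Pentyl Chain Replaces Tert-Butyl in a Weak Series

This account rests on a few compounds, and the source may have more. Where it says the series, first, only, none or still open, it means among the compounds named here.

Three compounds have been measured in a functional assay on HL-60 cells (Homo sapiens) for cytotoxicity, read by MTT assay, with a stated time of 72 h; a higher number here means a weaker inhibitor, a lower number a stronger inhibitor:
- compound 1, `Fc1ccc(-c2nnc3nnc(N4CCCCC4)nn23)cc1`, gives 30700 nM
- compound 2, `CC(C)c1nnc2nnc(N3CCCC3)nn12`, gives 71200 nM
- compound 3, `CC(C)(C)c1nnc2nnc(N3CCCC3)nn12`, gives > 100000 nM

Compound 3 stands at a limit of this assay rather than at a number, and the value given for compound 3 is a limit (the limit of > 100000 nM in this assay, at which 1 of the 3 values shown sits). Among the measured compounds shown here, compound 2 gives a number, and the single step with one change that the data hold runs from it: an at least 1.4-fold higher number from compound 2 to compound 3 (0.14 log units; that floor lies within the scatter). Compound 1 carries a different core substituent and a different amine, so its value only shows where a third member of the set sits.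

Compound 4, `CCCCCc1nnc2nnc(N3CCCC3)nn12`, has not yet been measured. It differs from compound 3 by pentyl in place of tert-butyl on an aromatic carbon. For the measured compounds named here, no measured step exchanges a branched chain for a linear one, so the one step known, from compound 2 to compound 3, bears on it only loosely: it was small and within scatter. Compound 4 is therefore expected to remain weak in this assay, with a step of an at least 1.1-fold lower number from compound 3 to compound 4 (0.04 log units; that floor lies within the scatter) that is expected to be no larger than the scatter. The estimate for compound 4 is 90000 nM, expected to fall between 35000 nM and 200000 nM.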

Compound 4, half-maximal inhibitory concentration: 42500 nM
Beside the measured number, compound 4's estimate is 2.1-fold (0.33 log units) above it; the measured number falls inside the stated range.
By their numbers in this assay, from the lowest: compounds 1, 4 and 2 (each within the scatter of the next, the first and the last beyond it). At a limit, above all of these: compound 3.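

In this assay, among the compounds shown here, the position on the aromatic carbon now shows a change beyond the scatter: pentyl in place of tert-butyl gives an at least 2.3-fold lower number from compound 3 to compound 4 (0.37 log units; beyond the scatter), whereas the only earlier step at this position, an at least 1.4-fold higher number from compound 2 to compound 3 (0.14 log units; that floor lies within the scatter), did not establish a change beyond the scatter. This size is only a floor, as the value for compound 3 is a limit: the limit of > 100000 nM in this assay, at which 1 of the 4 values shown sits. Pentyl in place of isopropyl gives a 1.7-fold lower number from compound 2 to compound 4 (0.22 log units; within the scatter), so these two chains cannot be told apart in this assay, and only the tert-butyl group is separated from pentyl.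

The step from tert-butyl to pentyl changes chain length and branching together, and the compounds shown do not separate the two. They also leave open how a shorter linear chain such as propyl, a longer one such as heptyl, or a pentyl chain ending in an amine or a carboxylic acid would read in this assay.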